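This account rests on a few compounds, and the source may have more. Where it says the series, first, only, none or still open, it means among the compounds named here.

In a functional assay on PC-3 cells (Homo sapiens) for antiproliferative activity, read by WST assay, with a stated time of 3 days (on this read-out lower numbers stand for stronger inhibition and higher numbers for weaker inhibition), compound 1 (`CCCCCOc1c(-c2cc(OC)c(OC)c(OC)c2)oc2ccccc2c1=O`) gives 22200 nM, and compound 2 (`CCCCCN(CCCCC)CCCCOc1c(-c2cc(OC)c(OC)c(OC)c2)oc2ccccc2c1=O`) gives 7900 nM, the lower of the two numbers. Compound 3 (`CCCCCN(CCCCC)CCCCCOc1c(-c2cc(OC)c(OC)c(OC)c2)oc2ccccc2c1=O`) differs from compound 2 as follows: (dipentylamino)methyl in place of dipentylamino on a saturated chain carbon, four bonds along the chain from an oxygen on an aromatic ring, with (dipentylamino)methyl in place of dipentylamino on a saturated chain carbon, four bonds along the chain from an oxygen on an aromatic ring. For the measured compounds named here, only one measured step bears on this, the modest 2.8-fold lower number from compound 1 to compound 2 (0.45 log units; beyond the scatter), and it replaced methyl with dipentylamino rather than making this change. No shift beyond the scatter is therefore expected in this assay, and the expected step is a 1.1-fold lower number from compound 2 to compound 3 (0.05 log units; within the scatter). For compound 3 the estimate is 7000 nM, with an expected range of 3000 nM to 16000 nM.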

Compound 3, half-maximal inhibitory concentration: 9600 nM
For compound 3 the middle estimate is 1.4-fold (0.14 log units) below the measured one, and the stated range covers the measured number.
By their numbers in this assay, from the lowest: compounds 2 and 3 (each within the scatter of the next); then compound 1.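

In this assay, (dipentylamino)methyl in place of dipentylamino on the saturated chain carbon gives a 1.2-fold higher number from compound 2 to compound 3 (0.08 log units; within the scatter), so at this position the change leaves the number within the scatter. With this chain, the amine-bearing compound still stands apart from the simple pentyl ether, with a 2.3-fold lower number from compound 1 to compound 3 (0.36 log units; beyond the scatter) as the step beyond the scatter. No available evidence explains either step. Still open, as far as these compounds go, is how a morpholine or a dimethylamino group at the chain end, or a much longer chain, would read out.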